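The source may report more compounds than this note shows. Statements on the series, on what has been measured and on what is new or still open speak of the compounds shown alone.

Compound 1 `O=C(/C=C/c1ccc(Cl)cc1)/C=C/c1ccc(Oc2cc(=O)oc3ccccc23)cc1`: 48300 nM
Compound 2 `COc1cc(OC)c2c(=O)c(OCCCCOc3ccccc3/C=C/C(=O)/C=C/c3ccco3)c(-c3cc(OC)c(OC)c(OC)c3)oc2c1`: 8980 nM

In a functional assay on SGC-7901 cells (Homo sapiens) for antiproliferative activity, read by MTT assay, with a stated time of 48 h (on this read-out lower numbers stand for stronger inhibition and higher numbers for weaker inhibition), compound 2 gives 8980 nM, the lowest of the two numbers, while compound 1 gives 48300 nM, and this gap lies beyond the usual scatter. Compound 3 `COc1cc(OC)c2c(=O)c(OCCCCOc3ccccc3/C=C/C(=O)/C=C/c3cccs3)c(-c3cc(OC)c(OC)c(OC)c3)oc2c1` differs from compound 2 only by thiophen-2-yl in place of furan-2-yl on a double-bonded chain carbon bound to a double-bonded chain carbon. For the measured compounds named here, no measured pair shows what such a swap does here, so the expectation rests on compound 2 alone. The step is expected to be small, likely within the scatter, as a 1.2-fold lower number from compound 2 to compound 3 (0.08 log units; within the scatter). Compound 3 is therefore estimated at 7500 nM, with a range from 3000 nM to 20000 nM.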

Compound 3, half-maximal inhibitory concentration: 26500 nM
Beside the measured number, compound 3's estimate is 3.5-fold (0.55 log units) below it, outside the stated range (above it).
By their numbers in this assay, from the lowest: compound 2; then compounds 3 and 1 (each within the scatter of the next).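

In this assay, the ring at this place on a double-bonded chain carbon bound to a double-bonded chain carbon matters: exchanging only oxygen for sulfur in a five-membered aromatic ring of equal size gives a 3.0-fold higher number from compound 2 to compound 3 (0.47 log units; beyond the scatter) and moves the number the weaker way. So even this close swap carries a cost beyond the scatter. No measurement here gives a reason for this shift. From the compounds shown here alone, whether a pyridin-2-yl ring or an amine at this place would match furan-2-yl stays open, as does whether furan-2-yl keeps its edge on another core.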